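The source may hold more compounds than are shown below. What is called first, only, known or untested is meant among the compounds shown, and "the series" means these compounds.

In a functional assay on PC-3 cells (Homo sapiens) for antiproliferative activity, read by MTT assay, with a stated time of 48 h (a higher number here means a weaker inhibitor, a lower number a stronger inhibitor), three compounds sharing one core have been measured. Compound 1 (`COc1ccc(CN(C(=O)CSc2nc3ccccc3s2)c2cc(OC)c(OC)c(OC)c2)cc1C`) gives 34300 nM. Compound 2 (`COc1ccc(CN(C(=O)CSc2nc3ccccc3s2)c2cc(OC)c(OC)c(OC)c2)cc1OC`) gives > 80000 nM, which is a limit of the assay and not a number. Compound 3 (`COc1ccc(CN(C(=O)CSc2nc3ccccc3s2)c2cc(OC)c(OC)c(OC)c2)cc1N`) gives 7510 nM, the lowest number of the set, and compound 1 is its nearest neighbour.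

Compound 4 (`COc1cc(N(Cc2ccc(Br)cc2)C(=O)CSc2nc3ccccc3s2)cc(OC)c1OC`) has 4-bromophenyl in place of 3-amino-4-methoxyphenyl on a saturated chain carbon bound to an amide-type nitrogen. Among the compounds with values here, no measured step makes this exchange, and none involves bromine, so the evidence is indirect. Two steps bring in the amino group: a 4.6-fold lower number from compound 1 to compound 3 (0.66 log units; beyond the scatter) is modest, and an at least 10-fold lower number from compound 2 to compound 3 (1.02 log units; beyond the scatter) is large. The third, an at least 2.3-fold higher number from compound 1 to compound 2 (0.36 log units; beyond the scatter), is at least modest and shows that the number in this assay also moves when methoxy replaces methyl.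

Compound 4 carries no amino group, so, going by a 4.6-fold lower number from compound 1 to compound 3 (0.66 log units; beyond the scatter), a modest step to a higher number is expected in this assay, and a larger one remains possible. The estimated change is a 3.3-fold higher number from compound 3 to compound 4 (0.52 log units; beyond the scatter). For compound 4 the expected value is 25000 nM, with an estimated range of 7000 nM to 80000 nM.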

Compound 4, half-maximal inhibitory concentration: > 80000 nM
Compound 4 ended at the assay's limit (the forecaster's own chance of this, stated with the estimate: 20%); middle value at least 3.2-fold (0.50 log units) away from the limit.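

In this assay, putting 4-bromophenyl in place of 3-amino-4-methoxyphenyl on a saturated chain carbon bound to an amide-type nitrogen gives an at least 10-fold higher number from compound 3 to compound 4 (1.02 log units; beyond the scatter), so the low number of compound 3 does not survive this exchange. The exchange of 4-methoxy-3-methylphenyl for 4-bromophenyl at the same place gives an at least 2.3-fold higher number from compound 1 to compound 4 (0.36 log units; beyond the scatter), which shows that a ring carrying bromine and no methoxy group also falls behind the weaker of the two compounds that gave a number. The earlier compounds had shown changes only among rings carrying a methoxy group, and the step from compound 2 to compound 4 cannot be read, because both compounds stand at one limit: the limit of > 80000 nM in this assay, at which 2 of the 4 values shown sit.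

Compound 4 differs from compound 3 in more than one group, so the compounds shown do not separate the loss of the amino and methoxy groups from the arrival of bromine. A ring carrying both an amino group and bromine, or one with chlorine or a hydroxyl group in place of bromine, would be needed to tell these apart.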